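Ester variation from compound 2 to compound 3

This account rests on a few compounds, and the source may have more. Where it says the series, first, only, none or still open, it means among the compounds named here.

Compound 2 `CC1=C(C(=O)OC2CCC2)C(c2ccsc2)NC(=O)N1` and compound 1 `CC1=C(C(=O)OCC2CC2)C(c2cccs2)NC(=O)N1` have been measured in an assay on membranes from HEK293 cells for displacement of a labelled ligand from adenosine receptor A2b (Homo sapiens), read by scintillation counting, with a stated time of 30 min; a lower number here means a stronger inhibitor, a higher number a weaker inhibitor. Compound 2 gives 405 nM in this assay, the lower of the two numbers; compound 1 gives 1570 nM, a gap beyond the scatter. Compound 3 `CC1=C(C(=O)OCC2CC2)C(c2ccsc2)NC(=O)N1` is not yet measured. It differs from compound 2 in one place: cyclopropylmethyl in place of cyclobutyl on an oxygen next to a carbonyl group. Among the measured compounds shown here, no measured pair shows this change on its own, so the step is expected to be small, within or only just beyond the scatter, and if anything toward a higher number. For compound 3 in this assay the estimate is 600 nM, with a range of 250 nM to 1500 nM. The expected step is a 1.5-fold higher number from compound 2 to compound 3 (0.17 log units; within the scatter).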

Compound 3, inhibition constant: 724 nM
For compound 3 the middle estimate is 1.2-fold (0.08 log units) below the measured one; low and high end bracket the measured number.
By their numbers in this assay, from the lowest: compounds 2 and 3 (each within the scatter of the next); then compound 1.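

In this assay, the ester exchange gives a 1.8-fold higher number from compound 2 to compound 3 (0.25 log units; within the scatter), and cyclobutyl and cyclopropylmethyl on this oxygen are not told apart. The thiophene exchange on the saturated ring carbon gives a 2.2-fold lower number from compound 1 to compound 3 (0.34 log units; beyond the scatter), a modest step, and it is the only step among these compounds that lies beyond the scatter. No measured evidence bears on either step.

Open, going by these compounds, is whether a longer chain or an amine-bearing chain on this oxygen leaves the number within the scatter. Also open, on these data alone, is how phenyl on the saturated ring carbon compares with thiophen-3-yl.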